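This account rests on a few compounds, and the source may have more. Where it says the series, first, only, none or still open, it means among the compounds named here.

Measured in an ADME assay on MT4 cells (Homo sapiens) for cytotoxicity, read by MTT assay, with a stated time of 5 days; a higher number here means that more compound is tolerated, a lower number that less compound is tolerated:

- compound 1 `COc1cc(-c2ccc(C#N)cc2)ccc1[C@H](O)c1ccnc(Nc2ccc(C#N)cc2)n1`: 9070 nM
- compound 2 `COc1cc(-c2ccc(C#N)cc2)ccc1C(O)c1ccnc(Nc2ccc(C#N)cc2)n1`: 13200 nM
- compound 3 `N#Cc1ccc(Nc2nccc(C(O)c3ccc(-c4ccc(C#N)cc4)cc3Cl)n2)cc1`: 7540 nM

The three values lie within the scatter of one another, so compound 3 sits level with compound 1 and compound 2 on these numbers. The next compound is compound 4 `N#Cc1ccc(Nc2nccc([C@@H](O)c3ccc(-c4ccc(C#N)cc4)cc3Cl)n2)cc1`, and its difference from compound 3 is the two compounds have the same atoms and bonds; at least one stereo element is drawn with a configuration in one of them and without one in the other: 1 of 1 stereo elements differ; a stereocentre at a saturated chain carbon is drawn without a configuration in compound 3 and S in compound 4. The stereocentre at a saturated chain carbon is thus drawn S in compound 4 and without a configuration in compound 3.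

Going by the values given here, the closest precedent is a 1.5-fold higher number from compound 1 to compound 2 (0.16 log units; within the scatter), which runs the opposite way with respect to the drawn configuration. Among the compounds with values here, the one difference behind that step is the fact that one of compounds 1 and 2 is drawn with a defined configuration and the other without, at the place where they differ. The other measured step, a 1.8-fold lower number from compound 2 to compound 3 (0.24 log units; within the scatter), concerns chloro in place of methoxy and only shows that compound 3 sits on the same level. Neither step leaves the scatter, so no step beyond the scatter is expected in this assay. The estimated change is a 1.2-fold lower number from compound 3 to compound 4 (0.06 log units; within the scatter). Compound 4 is expected at 6500 nM, with an estimated range from 3300 nM to 13000 nM.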

Compound 4, half-maximal cytotoxic concentration: 4250 nM
Compound 4: middle estimate off by 1.5-fold (0.18 log units), on the high side; the range from low to high includes it.
By their numbers in this assay, from the lowest: compounds 4, 3, 1 and 2 (each within the scatter of the next, the first and the last beyond it).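

In this assay, drawing the stereocentre at the saturated chain carbon as S on the chloro compounds gives a 1.8-fold lower number from compound 3 to compound 4 (0.25 log units; within the scatter), so this change stays inside the scatter on the chloro pair as it did on the methoxy pair. Going by these compounds alone, with the configuration drawn S on both sides, chloro in place of methoxy on the aromatic carbon gives a 2.1-fold lower number from compound 1 to compound 4 (0.33 log units; beyond the scatter), a modest step and the only one for this change that leaves the scatter. The two readings of that change still agree with each other: the same change on two cores in this assay, a 1.8-fold lower number (0.24 log units; within the scatter) from compound 2 to compound 3 and a 2.1-fold lower number (0.33 log units; beyond the scatter) from compound 1 to compound 4, 1.2-fold (0.09 log units) apart, within the scatter of two such steps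

The compounds shown leave open how a configuration drawn R at the chain carbon would read. They also leave open what a fluoro, a methyl or a dimethylamino group on that aromatic carbon would give.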